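The source may hold more compounds than are shown below. What is called first, only, known or untested is meant among the compounds shown, and "the series" means these compounds.

Compound 1: `O=C(c1cc(Cl)ccc1-c1ncccn1)N1CC2(CC2)C[C@H]1CNc1ccc(C(F)(F)F)cn1`, 8.1. Compound 2: `Cc1ccc(-c2ncccn2)c(C(=O)N2CC3(CC3)C[C@H]2CNc2ccc(Cl)cn2)c1`, 8.2.

In a functional assay on CHO cells for antagonist activity at Orexin/Hypocretin receptor type 1 (Homo sapiens), read by FLIPR and calcium flux (on this read-out higher numbers stand for higher potency (the scale is a negative logarithm) and lower numbers for lower potency), compound 2 gives 8.2, the higher of the two numbers, though the gap to compound 1 at 8.1 is within the scatter, so the two cannot be ranked. Compound 3 is `Cc1ccc(-c2ncccn2)c(C(=O)N2CC3(CC3)C[C@H]2CNc2ccc(C(F)(F)F)cn2)c1`; it differs from compound 2 by trifluoromethyl in place of chloro on an aromatic carbon. Going by the values given here, no step between measured compounds isolates this exchange, so there is no measured step to lean on. The step from compound 2 to compound 3 in this assay is expected to be small, no change at the digits printed from compound 2 to compound 3 (within the scatter), in neither direction beyond the scatter. Compound 3 is therefore estimated at 8.2, between 7.7 and 8.7.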

Compound 3, negative logarithm of the antagonist equilibrium constant: 8.7
The estimate for compound 3 lay 0.50 log units below the measured number; the range from low to high includes it.
By their numbers in this assay, from the lowest: compounds 1 and 2 (each within the scatter of the next); then compound 3.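

In this assay, trifluoromethyl in place of chloro on the pyridine group gives a number 0.50 log units higher from compound 2 to compound 3 (beyond the scatter), so this position responds to the exchange by more than the scatter. Methyl in place of chloro on an aromatic carbon of the other ring gives a number 0.60 log units higher from compound 1 to compound 3 (beyond the scatter), also beyond the scatter, so each of the two groups in compound 3 counts when set against chloro. Nothing measured here gives a reason for either step. From the compounds shown here alone, whether a nitrile or a methoxy group at the pyridine position would match trifluoromethyl remains open. So does whether the trifluoromethyl step would keep its size with chloro rather than methyl on the other ring.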